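The compounds below may be only part of what the source reports. "The series", "measured", "known", "first", "only" and "open" are said of these compounds alone.

Measured compounds:
Compound 1, `Nc1nc(-c2ncco2)nc2sc(Cc3ccccc3)cc12`, gives 310 nM in a functional assay on CHO-K1 cells for antagonist activity at adenosine receptor A1 (Homo sapiens), read by a beta-galactosidase reporter and cAMP accumulation, with stated times of 15 min and 6 h; a higher number here means a weaker inhibitor, a lower number a stronger inhibitor.
Compound 2, `Nc1nc(-c2cnco2)nc2sc(Cc3ccccc3)cc12`, gives 106 nM.
Compound 3, `Nc1nc(-c2cccc(F)c2)nc2sc(Cc3ccccc3)cc12`, gives 123 nM.

Among these three, compound 3 has the second highest number. Its nearest neighbour is compound 2, separated by a 1.2-fold higher number from compound 2 to compound 3 (0.06 log units; within the scatter), a gap within the scatter, while compound 1 lies furthest away, separated by a 2.5-fold lower number from compound 1 to compound 3 (0.40 log units; beyond the scatter). Compound 4, `Nc1nc(-c2ncccn2)nc2sc(Cc3ccccc3)cc12`, has not yet been measured. Compared with compound 3 it carries pyrimidin-2-yl in place of 3-fluorophenyl on an aromatic carbon. Within the data shown here, three measured steps bear on this change, all swaps of the group at this same position on the shared core. a 2.9-fold lower number from compound 1 to compound 2 (0.47 log units; beyond the scatter) and a 2.5-fold lower number from compound 1 to compound 3 (0.40 log units; beyond the scatter) show that replacing 1,3-oxazol-2-yl with either 1,3-oxazol-5-yl or 3-fluorophenyl gave a modest gain, whereas a 1.2-fold higher number from compound 2 to compound 3 (0.06 log units; within the scatter) shows those two replacements to be indistinguishable. Of the three measured groups, the entering pyrimidin-2-yl most resembles the 1,3-oxazol-2-yl of compound 1, the weakest of the set. A modest move back toward a higher number is therefore expected, though it may not clear the scatter. Compound 4 is expected to give about 220 nM, within 80 nM to 650 nM. The step implied for compound 4 is estimated as a 1.8-fold higher number from compound 3 to compound 4 (0.25 log units; within the scatter).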

Compound 4, inhibition constant: 618 nM
Compound 4: the middle estimate sits 2.8-fold (0.45 log units) below what was measured; the measured number falls inside the stated range.
By their numbers in this assay, from the lowest: compounds 2 and 3 (each within the scatter of the next); then compounds 1 and 4 (each within the scatter of the next).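

In this assay, a six-membered aromatic ring at this position does not by itself secure the lower numbers: replacing 3-fluorophenyl, a ring of carbon only, with pyrimidin-2-yl, a ring with 2 hetero atoms, gives a 5.0-fold higher number from compound 3 to compound 4 (0.70 log units; beyond the scatter). Pyrimidin-2-yl also compares poorly with 1,3-oxazol-5-yl, with a 5.8-fold higher number from compound 2 to compound 4 (0.77 log units; beyond the scatter), yet it cannot be told apart from 1,3-oxazol-2-yl, with a 2.0-fold higher number from compound 1 to compound 4 (0.30 log units; within the scatter), so the four groups now fall into two pairs: compounds 2 and 3 at the lower numbers, compounds 1 and 4 at the higher ones. Ring size does not sort these groups, since each pair holds one five-membered and one six-membered ring.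

Nothing measured here explains why the groups divide this way. Still open, on these data alone, is whether plain phenyl or pyridin-2-yl at this position would join compounds 2 and 3 or compounds 1 and 4, which would help show whether the fluorine of compound 3 or the ring nitrogens of compound 4 track with the change in number.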